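The source may report more compounds than this note shows. Statements on the series, on what has been measured and on what is new or still open speak of the compounds shown alone.

Going by the values given here, in a functional assay on Caco-2 cells (Homo sapiens) for inhibition, read by MTT assay, with a stated time of 48 h, tested at 10 uM (on this read-out lower numbers stand for less inhibition of growth and higher numbers for more inhibition of growth at the one concentration tested), only two compounds have numbers so far, and both lie low on the scale. Compound 1 `Cc1oc2c([C@H]3CCN(C)C[C@H]3O)c(O)cc(O)c2c(=O)c1C(O)c1ccc(Cl)cc1` gives 3%, and compound 2 `Cc1oc2c([C@H]3CCN(C)C[C@H]3O)c(O)cc(O)c2c(=O)c1C(O)c1ccccc1Br` gives 7%. With so few values, compound 2 stands level with compound 1, and the two cannot be told apart.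

The next compound, compound 3 `Cc1oc2c([C@H]3CCN(C)C[C@H]3O)c(O)cc(O)c2c(=O)c1C(O)c1c(Cl)cccc1Cl`, keeps the shared core and alters one group: 2,6-dichlorophenyl in place of 2-bromophenyl on a saturated chain carbon bound to an aromatic carbon and an oxygen on a saturated carbon. Here 2,6-dichlorophenyl takes the place of 2-bromophenyl on a saturated chain carbon bound to an aromatic carbon and an oxygen on a saturated carbon.

Among the compounds with values here, one measured step bears on this change. It was made at the same place, when 2-bromophenyl took over from 4-chlorophenyl, and it gave a number 4 percentage points higher from compound 1 to compound 2 (within the scatter), so no step beyond the scatter is expected in this assay this time either. Within the data shown here, no measured compound carries the 2,6-dichlorophenyl group, however, so this expectation rests on thin evidence.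

The expected change is a number 1 percentage points lower from compound 2 to compound 3 (within the scatter), which would stay within the scatter. The estimate for compound 3 is 6%, with an expected range from 0% to 17%.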

Compound 3, percent growth inhibition at one concentration: 24%
Compound 3: middle estimate off by 18 percentage points, on the low side, and the stated range ends below it.
By their numbers in this assay, from the lowest: compounds 1 and 2 (each within the scatter of the next); then compound 3.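

The aryl group on this saturated chain carbon, bound to an aromatic carbon and an oxygen on a saturated carbon, does not leave this assay unchanged whichever group is placed there. The earlier swap of 4-chlorophenyl for 2-bromophenyl stayed within the scatter, whereas 2,6-dichlorophenyl gives a number 17 percentage points higher from compound 2 to compound 3 (beyond the scatter) and, measured against the 4-chlorophenyl compound, gives a number 21 percentage points higher from compound 1 to compound 3 (beyond the scatter) as well, so the two earlier compounds now serve as a common low reference for a clear rise. Nothing measured here explains why this one aryl group stands apart from the other two at this position.

The compounds shown leave open whether the rise depends on chlorine itself or on the pattern of substitution in the 2,6-dichlorophenyl group, a question that a 2,6-dimethylphenyl or 2,6-difluorophenyl group at the same carbon, read against an unsubstituted phenyl group, could begin to answer. They also leave open how far the rise can go at this carbon, and whether a ring carrying an amine or a carboxylic acid would be tolerated there at all.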